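From compound 3 to compound 4: an open chain

This account rests on a few compounds, and the source may have more. Where it says the series, first, only, none or still open, it means among the compounds named here.

In a functional assay on Ishikawa cells (Homo sapiens) for antiproliferative activity, read by CCK-8 assay, with a stated time of 48 h (a higher number here means a weaker inhibitor, a lower number a stronger inhibitor), compound 3 (`C/C=C/C(=O)N1CC(Oc2ccc(Oc3c(-c4ccc(F)cc4)sc4cc(O)ccc34)cc2)C1`) gives 9400 nM and compound 1 (`O=C(/C=C/CNCCOc1ccc(Oc2c(-c3ccc(F)cc3)sc3cc(O)ccc23)cc1)N1CCCC1`) gives 11300 nM, two values within the scatter of each other. Compound 2 (`C=C(C)C(=O)NCCOc1ccc(Oc2c(-c3ccc(F)cc3)sc3cc(O)ccc23)cc1`) gives > 25000 nM, which is a limit of the assay and not a number.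

Compound 4 (`CNC(=O)/C=C/CNCCOc1ccc(Oc2c(-c3ccc(F)cc3)sc3cc(O)ccc23)cc1`) has not yet been measured. It carries 2-((3-(methylcarbamoyl)prop-2-en-1-yl)amino)ethyl in place of 1-((prop-1-en-1-yl)carbonyl)azetidin-3-yl on an oxygen on an aromatic ring.

Going by the values given here, two measured steps bear on this change. The first is an at least 2.2-fold higher number from compound 1 to compound 2 (0.34 log units; beyond the scatter), and the second is an at least 2.6-fold lower number from compound 2 to compound 3 (0.42 log units; beyond the scatter). From the compounds shown here alone, both lie beyond the scatter, but both rest on the limit of compound 2, so their true sizes remain open. Compound 4 keeps an open chain with a substituted prop-2-en-1-yl group on the amine nitrogen, as compound 1 does at 11300 nM, and it lacks the (1-methylethenyl)carbonyl group of compound 2. Going by these compounds, its number is therefore expected to lie close to those of compound 1 and compound 3 rather than at the limit, although the methylcarbamoyl end remains untested.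

The expected change is a 1.3-fold higher number from compound 3 to compound 4 (0.11 log units; within the scatter), and no step beyond the scatter is expected. For compound 4, the estimated value is 12000 nM, with an expected range of 6000 nM to 25000 nM.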

Compound 4, half-maximal inhibitory concentration: 15500 nM
The estimate for compound 4 lay 1.3-fold (0.11 log units) below the measured number; the range from low to high includes it.
By their numbers in this assay, from the lowest: compounds 3, 1 and 4 (each within the scatter of the next). At a limit, above all of these: compound 2.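

Replacing 1-((prop-1-en-1-yl)carbonyl)azetidin-3-yl on an oxygen on an aromatic ring with the open 2-((3-(methylcarbamoyl)prop-2-en-1-yl)amino)ethyl chain gives a 1.6-fold higher number from compound 3 to compound 4 (0.22 log units; within the scatter) in this assay, so this position accepts both the ring and the open chain without a change beyond the scatter. At the far end of the open chain, methylamino in place of pyrrolidin-1-yl on a carbonyl carbon gives a 1.4-fold higher number from compound 1 to compound 4 (0.14 log units; within the scatter) in this assay, which shows that this exchange on the carbonyl does not separate the two compounds in this assay. From the compounds shown here alone, the comparison on the amine nitrogen, 3-(methylcarbamoyl)prop-2-en-1-yl in place of (1-methylethenyl)carbonyl, gives only a floor, an at least 1.6-fold lower number from compound 2 to compound 4 (0.20 log units; that floor lies within the scatter) in this assay, and the true size of that step stays unknown, as one end of it is a limit and not a number: the limit of > 25000 nM in this assay, at which 1 of the 4 values shown sits.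

Going by these compounds, it remains open whether a larger piperidine amide or a free carboxylic acid at the carbonyl end would move the number beyond the scatter. On these data alone, it is also open whether the amine nitrogen of the chain matters, which an ether oxygen in its place would test.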